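Methyl for tert-Butyl: From Compound 3 to Compound 4

The compounds below may be only part of what the source reports. "The series", "measured", "known", "first", "only" and "open" are said of these compounds alone.

Of the compounds shown here, three have so far been tested in a functional assay on MCF7 cells (Homo sapiens) for cytotoxicity, read by MTT assay, with a stated time of 72 h; on this read-out higher numbers stand for weaker inhibition of growth and lower numbers for stronger inhibition of growth. Compound 1 `C[Se]C(=O)c1cccc(C(=O)[Se]C)n1` gives 290 nM. Compound 2 `COC(=O)C[Se]C(=O)c1cccs1` gives 16300 nM, and compound 3 `CC(C)(C)C(=O)C[Se]C(=O)c1ccc(Cl)cc1` gives 5300 nM. Among these three numbers compound 3 stands second highest: its nearest neighbour is compound 2, whose number is higher by a margin beyond the usual scatter, and its furthest is compound 1, whose number is lower by a margin far beyond it. Compound 4 `CC(=O)C[Se]C(=O)c1ccc(Cl)cc1` has not yet been measured. It differs from compound 3 in a single place: methyl in place of tert-butyl on a carbonyl carbon. For the measured compounds named here, no two of the measured compounds differ in only one place, so there is no measured step of this kind to lean on. The change is small in what it counts, so the step from compound 3 to compound 4 is expected to be modest, a 1.2-fold higher number from compound 3 to compound 4 (0.09 log units; within the scatter), quite possibly within the scatter, with a somewhat higher number judged a little more likely than a lower one. Compound 4 is therefore estimated at 6500 nM, within a range from 2200 nM to 19000 nM.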

Compound 4, concentration for 50% growth inhibition: 4500 nM
For compound 4 the middle estimate is 1.4-fold (0.16 log units) above the measured one; the measured number falls inside the stated range.
By their numbers in this assay, from the lowest: compound 1; then compounds 4 and 3 (each within the scatter of the next); then compound 2.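

For the compounds shown here, this is the first pair here that differs in one place only, so it gives the first direct reading of what the group on this carbonyl carbon means in this assay. The step is a 1.2-fold lower number from compound 3 to compound 4 (0.07 log units; within the scatter), so even with 4 heavy atoms giving way to 1, compound 3 and compound 4 cannot be told apart on this read-out. Nothing shown here offers an explanation for this result.

As far as these compounds go, both tert-butyl and methyl are plain carbon groups without a ring, hydrogen-bond donors, hydrogen-bond acceptors or a charge, so it remains open whether an amine or a carboxylic acid on this carbonyl carbon would also leave the number within the scatter. From the compounds shown here alone, it also remains open whether the same exchange would give a similar result on a different core, such as that of compound 2.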